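The source may hold more compounds than are shown below. What is called first, only, known or untested is meant among the compounds shown, and "the series" means these compounds.

The series shares the core of compound 1 `CC1=CC[C@H](C(C)(C)NC(=S)NN)CC1`, which in a functional assay on HT-29 cells (Homo sapiens) for inhibition, read by sulforhodamine B assay, with a stated time of 48 h (on this read-out higher numbers stand for weaker inhibition of growth and lower numbers for stronger inhibition of growth), gives 60100 nM. Compound 2 `COc1ccc(/C=N/NC(=S)NC(C)(C)[C@H]2CC=C(C)CC2)cc1`, which carries a 4-methoxyphenyl group on the carbon double-bonded to nitrogen, gives 8400 nM in this assay, the lowest of the three numbers available, with compound 3 as its nearest neighbour and compound 1 furthest away. Compound 3 `CC1=CC[C@H](C(C)(C)NC(=S)N/N=C/c2ccc(N(C)C)cc2)CC1` gives 46500 nM. For the measured compounds named here, the single measured step that alters one place is a 5.5-fold higher number from compound 2 to compound 3 (0.74 log units; beyond the scatter). Compound 4 `CC1=CC[C@H](C(C)(C)NC(=S)N/N=C/c2ccccc2Cl)CC1` has not yet been tested; it differs from compound 2 in that (2-chlorophenyl in place of 4-methoxyphenyl on a carbon with a double bond to nitrogen). Going by the values given here, no measured pair exchanges the methoxy for a chlorine, so the only comparison that bears on compound 4 is the step from compound 2 to compound 3, which weakened inhibition by a modest amount. Exchanging the aromatic substituent of compound 2 is therefore expected to cost rather than gain activity, with the new group lacking the single acceptor the old one had. The expected step from compound 2 to compound 4 is a 1.8-fold higher number from compound 2 to compound 4 (0.25 log units; within the scatter). Compound 4 is thus estimated to give 15000 nM, within a range from 5000 nM to 45000 nM.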

Compound 4, concentration for 50% growth inhibition: 71300 nM
The estimate for compound 4 lay 4.8-fold (0.68 log units) below the measured number; measured number outside the range, above it.
By their numbers in this assay, from the lowest: compound 2; then compounds 3, 1 and 4 (each within the scatter of the next).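

In this assay, the result adds a second replacement of the 4-methoxyphenyl group on the carbon with a double bond to nitrogen, and it gives an 8.5-fold higher number from compound 2 to compound 4 (0.93 log units; beyond the scatter). Together with a 5.5-fold higher number from compound 2 to compound 3 (0.74 log units; beyond the scatter), this shows that two different exchanges at this place both raise the number beyond the scatter, and compounds 3, 1 and 4 form a run in which each number lies within the scatter of the next, leaving compound 2 alone at the low end. No measurement is available that would explain why the 2-chlorophenyl group behaves in this way.

Because 2-chlorophenyl differs from 4-methoxyphenyl in both the substituent and its numbered ring position, the compounds shown cannot separate the loss of the methoxy group from the change of position. They also leave open how an unsubstituted phenyl ring, or an ethoxy or hydroxyl group in place of the methoxy, would compare with compound 2 8400 nM.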